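Replacing the isopropyl group of compound 3

A few compounds are considered here, and "the series" means these few. Any claim that something is new, unique, unknown or untested is made for them only; others in the source may bear on it.

Compound 1 `CCc1c(C)[nH]c2cc(OC)c(Cl)cc2c1=O`: 57.3 10^-6 cm/s
Compound 2 `COc1cc2[nH]c(C)c(C)c(=O)c2cc1Cl`: 59.2 10^-6 cm/s
Compound 3 `COc1cc2[nH]c(C)c(C(C)C)c(=O)c2cc1Cl`: 187 10^-6 cm/s

In an ADME assay for permeability, using PAMPA, at pH 7.4 (a lower number here means that the compound crosses the layer more slowly, a higher number that the compound crosses the layer faster), compound 3 stands highest of the three measured compounds, with 187 10^-6 cm/s, while compound 1 and compound 2 lie within the scatter of each other. Compound 4 `C=C(CCCCC)c1c(C)[nH]c2cc(OC)c(Cl)cc2c1=O` departs from compound 3 at a single place: a group of 7 heavy atoms (7 carbon; no ring) in place of a group of 3 heavy atoms (3 carbon; no ring), on an aromatic carbon. The change sits on an aromatic carbon, ortho to a methyl group and two atoms from the ring nitrogen, and the entering group carries 1 double bond outside aromatic rings.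

Going by the values given here, three measured steps concern this same place. The closest puts isopropyl in place of methyl on an aromatic carbon, with a 3.2-fold higher number from compound 2 to compound 3 (0.50 log units; beyond the scatter). A second step is of similar, modest size, with a 3.3-fold higher number from compound 1 to compound 3 (0.51 log units; beyond the scatter). The third stays within the scatter, with a 1.0-fold higher number from compound 1 to compound 2 (0.01 log units; within the scatter). None of these steps reaches a group as large as the one entering here, so they do not fix a direction for this change. No shift beyond the scatter is therefore expected, although the uncertainty is wide. The expected change is a 1.1-fold higher number from compound 3 to compound 4 (0.05 log units; within the scatter). For compound 4, the estimated value in this assay is 210 10^-6 cm/s, with an expected range from 70 10^-6 cm/s to 480 10^-6 cm/s.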

Compound 4, apparent permeability: 755 10^-6 cm/s
Estimate against measurement, compound 4: 3.6-fold (0.56 log units) below; measured number above the stated range.
By their numbers in this assay, from the lowest: compounds 1 and 2 (each within the scatter of the next); then compound 3; then compound 4.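

In this assay, the position on the aromatic carbon takes a far larger group than any earlier compound carried: the open-chain group of 7 heavy atoms, with its double bond outside aromatic rings, gives a 4.0-fold higher number from compound 3 to compound 4 (0.61 log units; beyond the scatter) in place of isopropyl. Against the smaller groups the same place shows large steps, with a 13-fold higher number from compound 2 to compound 4 (1.11 log units; beyond the scatter) and a 13-fold higher number from compound 1 to compound 4 (1.12 log units; beyond the scatter), so the rise seen with isopropyl goes on with this larger group instead of levelling off, although compound 1 and compound 2 go against any simple link with group size, their values lying within the scatter of each other. Nothing at hand explains why this group gives so much higher a number.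

The compounds shown leave open whether the step belongs to the double bond or to the length of the chain, as compound 4 brings both in together and a saturated chain of the same count would separate them. They also leave open whether a longer chain, a cyclohexyl ring or an amine at the end of the chain would hold the number at this level.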